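The compounds below may be only part of what the source reports. "The series", "measured", "known", "first", "only" and "open" are said of these compounds alone.

Measured compounds in a functional assay on PC-3 cells (Homo sapiens) for cytotoxicity, read by MTT assay, with a stated time of 48 h; on this read-out higher numbers stand for weaker inhibition and lower numbers for stronger inhibition:
compound 1 `Cc1ccc(Cn2c(/C=C3\SC(=S)N(CC(=O)O)C3=O)nc3cc(Cl)ccc32)cc1`, 26700 nM
compound 2 `Cc1ccc(Cn2c(/C=C3\SC(=S)N(CC(=O)O)C3=O)nc3ccc(Cl)cc32)cc1`, 1520 nM
compound 3 `Cc1ccc(Cn2c(/C=C3\SC(=S)N(CC(=O)O)C3=O)nc3cc(F)ccc32)cc1`, 10200 nM

Compound 1 and compound 2 are built from the same atoms joined differently; the difference between the two cores is not broken down here. Compound 2 gives the lowest number of the three, with compound 3 nearest and compound 1 furthest, both gaps beyond the scatter. From compound 1 to compound 3 the change is fluoro in place of chloro on an aromatic carbon, and the step is a 2.6-fold lower number from compound 1 to compound 3 (0.42 log units; beyond the scatter).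

Compound 4 `Cc1ccc(Cn2c(/C=C3\SC(=S)N(CC(=O)O)C3=O)nc3ccc(F)cc32)cc1` is not yet measured in this assay. It differs from compound 2 by fluoro in place of chloro on an aromatic carbon, the same change at a place described in the same words. Going by the values given here, for compound 4 a step of a 2.3-fold lower number from compound 2 to compound 4 (0.37 log units; beyond the scatter) is expected, resting on the single observed step of a 2.6-fold lower number from compound 1 to compound 3 (0.42 log units; beyond the scatter) with room for it to come out smaller on a more potent starting point. Compound 4 is therefore expected to give about 650 nM, between 250 nM and 1800 nM.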

Compound 4, half-maximal inhibitory concentration: 5820 nM
For compound 4 the middle estimate is 9.0-fold (0.95 log units) below the measured one, outside the stated range (above it).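

In this assay the exchange of chloro for fluoro does not carry over from one core to the other: the same change on two cores in this assay, a 2.6-fold lower number (0.42 log units; beyond the scatter) from compound 1 to compound 3 and a 3.8-fold higher number (0.58 log units; beyond the scatter) from compound 2 to compound 4, 10-fold (1.00 log units) apart, beyond the scatter of two such steps. The new step is a 3.8-fold higher number from compound 2 to compound 4 (0.58 log units; beyond the scatter) and runs in the opposite direction to the earlier one. This shows that, for these two pairs, the size and direction of the step depend on the core, but it does not show which feature of the cores sets them or how the change would behave on a further core.

Only chloro and fluoro appear at these ring positions in the compounds shown. On these data alone, whether a methoxy or a nitrile on either core would follow compound 2 or compound 1 remains open.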